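This account rests on a few compounds, and the source may have more. Where it says the series, first, only, none or still open, it means among the compounds named here.

In a functional assay on MDA-MB-231 cells (Homo sapiens) for antiproliferative activity, read by trypan blue exclusion, with a stated time of 24 h (a lower number here means a stronger inhibitor, a higher number a weaker inhibitor), compound 1 `O=C1NC(=O)/C(=C/c2cn(Cc3ccc([N+](=O)[O-])cc3)c3ccccc23)N1` gives 23300 nM and compound 2 `COC(=O)c1ccc(Cn2cc(/C=C3\NC(=O)NC3=O)c3ccccc32)cc1` gives 18400 nM. For the measured compounds named here, compound 2 therefore stands level with the only other measured compound, since the two values lie within the scatter of each other. Compound 3 `Cc1ccc(Cn2cc(/C=C3\NC(=O)NC3=O)c3ccccc32)cc1` keeps the shared core and changes one group: methyl in place of methoxycarbonyl on an aromatic carbon, para to a large group (methyl in place of methoxycarbonyl on an aromatic carbon). Going by the values given here, only one measured step bears on this change, the replacement of nitro by methoxycarbonyl on an aromatic carbon, which gave a 1.3-fold lower number from compound 1 to compound 2 (0.10 log units; within the scatter). That single step involves no methyl, so it is a thin guide, but it offers no reason to expect a real shift. The expected result in this assay is a 1.1-fold higher number from compound 2 to compound 3 (0.04 log units; within the scatter), which means no step beyond the scatter. For compound 3 the estimated value is 20000 nM, with an expected range of 10000 nM to 40000 nM.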

Compound 3, half-maximal inhibitory concentration: 22100 nM
Compound 3: middle estimate off by 1.1-fold (0.04 log units), on the low side; the measured number falls inside the stated range.
By their numbers in this assay, from the lowest: compounds 2, 3 and 1 (each within the scatter of the next).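

In this assay, methyl on this aromatic carbon, para to a large group, gives a 1.2-fold higher number from compound 2 to compound 3 (0.08 log units; within the scatter), and methyl in place of nitro gives a 1.1-fold lower number from compound 1 to compound 3 (0.02 log units; within the scatter). For the compounds shown here, the earlier pair compared only nitro and methoxycarbonyl, whereas methyl brings the group down to one heavy atom with no hydrogen-bond acceptors, against four heavy atoms and two acceptors in methoxycarbonyl, and still no step leaves the scatter. No measurement shown here gives a reason for this flat result. From the compounds shown here alone, three groups at one position cannot show whether this site is insensitive to every substituent, so it remains open whether an amine, a carboxylic acid or a longer chain there would shift the number beyond the scatter. Going by these compounds, whether the same holds at other places on this ring also remains open.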